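Carboxy to methoxycarbonyl: working notes on the series

A few compounds are considered here, and "the series" means these few. Any claim that something is new, unique, unknown or untested is made for them only; others in the source may bear on it.

Values in a physicochemical assay for solubility, read by spectrophotometry, in phosphate buffer, with a stated time of 18 h, at pH 7.4; a lower number here means a less soluble compound, a higher number a more soluble compound:
- compound 1 `CCc1ccc(-c2nc3c(c(C)nn3-c3ccccc3)c(-c3ccccc3C#N)c2C#N)cc1`: 2400 nM
- compound 2 `CCc1ccc(-c2nc3c(c(C)nn3-c3ccccc3)c(-c3ccccc3C(=O)O)c2C#N)cc1`: 33000 nM
- compound 3 `CCc1ccc(-c2nc3c(c(C)nn3-c3ccccc3)c(-c3ccccc3C(=O)OC)c2C#N)cc1`: not yet measured

Compound 2 stands higher of the two measured compounds, at 33000 nM. Going on to compound 3 is methyl in place of hydrogen on an oxygen next to a carbonyl group, or carboxy to methoxycarbonyl. Among the compounds with values here, only one measured step bears on this: a 14-fold higher number from compound 1 to compound 2 (1.14 log units; beyond the scatter), a large step with carboxy in place of cyano on an aromatic carbon. Like compound 1, compound 3 has no carboxy group, so a large step to a lower number is expected in this assay, of similar size to that one. Within the data shown here, no methoxycarbonyl compound has been measured, so the range is kept wide. The estimated step is a 13-fold lower number from compound 2 to compound 3 (1.12 log units; beyond the scatter). For compound 3 the expected value is 2500 nM, with an estimated range of 600 nM to 10000 nM.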

Compound 3, solubility: 17000 nM
Compound 3: middle estimate off by 6.8-fold (0.83 log units), on the low side; the whole stated range lies below it.
By their numbers in this assay, from the lowest: compound 1; then compounds 3 and 2 (each within the scatter of the next).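

In this assay the hydrogen on the oxygen of the carboxy group is not needed to stay level with compound 2, as methyl in its place gives a step within the scatter (a 1.9-fold lower number from compound 2 to compound 3 (0.29 log units; within the scatter)). The step from the nitrile therefore does not belong to the carboxy group alone, since methoxycarbonyl in place of cyano on the same aromatic carbon also ends beyond the scatter (a 7.1-fold higher number from compound 1 to compound 3 (0.85 log units; beyond the scatter)). No measurement shown accounts for this result.

From the compounds shown here alone, whether a longer ester such as ethoxycarbonyl, a primary amide or a hydroxymethyl group would read with compound 3 or with compound 1 stays open. Also open, going by these compounds, is whether carboxy to methoxycarbonyl reads the same way when the ethyl group on the shared core is replaced by a different group.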